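The source may report more compounds than this note shows. Statements on the series, on what has been measured and on what is new or still open speak of the compounds shown alone.

Working notes on the series. In a functional assay on KB cells (Homo sapiens) for cytotoxicity (on this read-out lower numbers stand for stronger inhibition and higher numbers for weaker inhibition), compound 1 (`O=S(=O)(N/C(=N\O)Nc1ccc(Cl)cc1)c1cccc2snnc12`) gives 35 ug/mL and compound 2 (`O=[N+]([O-])c1ccc(Oc2c(Cl)cc(S(=O)(=O)N/C(=N\O)Nc3ccc(Cl)cc3)cc2Cl)cc1`) gives 12 ug/mL. Compound 2 thus holds the lower of the two numbers, with a gap beyond the scatter. Compound 3 (`O=[N+]([O-])c1ccc(Oc2c(Cl)cc(S(=O)(=O)N/C(=N\O)Nc3ccc(Cl)cc3)cc2Cl)c(Cl)c1`), not yet measured, differs from compound 2 in one place: chloro in place of hydrogen on an aromatic carbon, ortho to a large group and meta to a nitro group. Among the compounds with values here, no measured step covers this change, so no shift beyond the scatter is expected in this assay. The expected step is a 1.2-fold lower number from compound 2 to compound 3 (0.08 log units; within the scatter). For compound 3 the estimated value is 10 ug/mL, with an expected range of 4 ug/mL to 25 ug/mL.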

Compound 3, half-maximal inhibitory concentration: 7 ug/mL
The estimate for compound 3 lay 1.4-fold (0.15 log units) above the measured number; measured number inside the range.
By their numbers in this assay, from the lowest: compounds 3 and 2 (each within the scatter of the next); then compound 1.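

Within the data shown here, replacing 4-nitrophenoxy with 2-chloro-4-nitrophenoxy gives the only single-place comparison here, and in this assay it reads as a 1.7-fold lower number from compound 2 to compound 3 (0.23 log units; within the scatter). This place, ortho to a large group and meta to a nitro group, therefore accepts chloro in place of hydrogen with no shift beyond the scatter. Nothing available speaks to the origin of this step. Going by these compounds, whether a methoxy group, an amine or a carboxylic acid at this place would move the number beyond the scatter remains open.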